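Aryl changes at the chain end of the shared core

The source may report more compounds than this note shows. Statements on the series, on what has been measured and on what is new or still open speak of the compounds shown alone.

Among the measured compounds shown here, compound 2 `COc1ccc(C(=O)/C=C/c2ccc(N(C)C)cc2)c2c1C=CC(C)(C)O2` is the only member with a number in a functional assay on HT-29 cells (Homo sapiens) for antiproliferative activity, read by MTT assay, with a stated time of 24 h; a lower number here means a stronger inhibitor, a higher number a weaker inhibitor: compound 2 gives 1870 nM. Compound 1 `COc1ccc(C(=O)/C=C/c2cccc(F)c2)c2c1C=CC(C)(C)O2` in this assay gives > 10000 nM, a limit of the assay and not a number. Compound 3 `COc1ccc(C(=O)/C=C/c2ccc(O)cc2)c2c1C=CC(C)(C)O2` in this assay gives > 10000 nM, again a limit and not a number. The point the limit of > 10000 nM in this assay, at which 2 of the 3 values shown sit, is thus where two of the three results stand. Compound 4 `COc1ccc(C(=O)/C=C/c2cccc(O)c2)c2c1C=CC(C)(C)O2` carries 3-hydroxyphenyl in place of 4-(dimethylamino)phenyl on a double-bonded chain carbon bound to a double-bonded chain carbon. For the measured compounds named here, two measured steps bear on this change: an at least 5.3-fold higher number from compound 2 to compound 3 (0.72 log units; beyond the scatter) and an at least 5.3-fold lower number from compound 1 to compound 2 (0.72 log units; beyond the scatter), both beyond the scatter. A step of at least similar size in the same direction is therefore expected in this assay, most likely ending at the limit again. Compound 4 is estimated at 15000 nM, range 4000 nM to 60000 nM. The expected step is an 8.0-fold higher number from compound 2 to compound 4 (0.90 log units; beyond the scatter).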

Compound 4, half-maximal inhibitory concentration: > 10000 nM
Compound 4: no number, only a limit; the forecaster's own chance of this, stated with the estimate: 75%; the middle value lies beyond the limit too.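

In this assay, 3-hydroxyphenyl in place of 4-(dimethylamino)phenyl gives an at least 5.3-fold higher number from compound 2 to compound 4 (0.72 log units; beyond the scatter). Compound 4 joins compound 3 at a limit of the assay, so neither hydroxyphenyl group shown gives a number, and compound 2 remains the only member with one. The steps among compound 1, compound 3 and compound 4 cannot be read, and the series now stands mostly at this limit: the limit of > 10000 nM in this assay, at which 3 of the 4 values shown sit.

On these data alone, it remains open whether a number depends on dimethylamino itself. A primary amine or a methoxy group in place of dimethylamino on the aromatic carbon would test this.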